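Amine swap on the thiocarbonyl carbon of compound 1

A few compounds are considered here, and "the series" means these few. Any claim that something is new, unique, unknown or untested is made for them only; others in the source may bear on it.

Compound 1 `COc1ccc2occ(CSC(=S)N3CCCC3)c(=O)c2c1` gives in a functional assay on MCF7 cells (Homo sapiens) for antiproliferative activity, read by MTT assay, with a stated time of 72 h (on this read-out lower numbers stand for stronger inhibition and higher numbers for weaker inhibition), a value of 34100 nM, the higher of the two numbers in hand. Compound 2 `O=c1c(Cl)c(CSC(=S)N2CCCCC2)oc2ccccc12` differs from compound 1 in more than one place; in this assay compound 2 gives a value of 1000 nM, a lower number that lies beyond the usual scatter. Compound 3 `COc1ccc2occ(CSC(=S)N3CCOCC3)c(=O)c2c1` has not yet been measured. It differs from compound 1 in one place: morpholin-4-yl in place of pyrrolidin-1-yl on a thiocarbonyl carbon. Going by the values given here, no step between measured compounds that differ in a single place is available, so the expectation rests on the structural change alone. A change of this kind on the thiocarbonyl carbon is expected to shift the number little; the expected step in this assay is a 1.2-fold higher number from compound 1 to compound 3 (0.07 log units; within the scatter), within the scatter, in either direction. For compound 3 the estimated value in this assay is 40000 nM, with a range from 12000 nM to 130000 nM.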

Compound 3, half-maximal inhibitory concentration: 11800 nM
Beside the measured number, compound 3's estimate is 3.4-fold (0.53 log units) above it, outside the stated range (below it).
By their numbers in this assay, from the lowest: compound 2; then compound 3; then compound 1.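

In this assay, going by these compounds alone, the amine on the thiocarbonyl carbon does affect the number: morpholin-4-yl in place of pyrrolidin-1-yl gives a 2.9-fold lower number from compound 1 to compound 3 (0.46 log units; beyond the scatter) on an otherwise unchanged core, a modest step but the first single-place reading. The change brings a six-membered ring and a hydrogen-bond acceptor together, so this one step cannot assign the shift to either feature alone. No measurement in hand explains the step.

Still open, as far as these compounds go, is how an open-chain amine such as diethylamino, or a piperazine ring bearing a methyl group on its second nitrogen, would read on the core of compound 1. Also open, from the compounds shown here alone, is whether the same amine swap gives a step of similar size on other cores.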